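The source may report more compounds than this note shows. Statements on the series, on what has been measured and on what is new or still open speak of the compounds shown alone.

Compound 1 `O=C1COC(c2ccc(NC(=O)Nc3cccc(Cl)c3)cc2)=NN1` and compound 2 `O=C1COC(c2ccc(/N=C/c3cccc(Cl)c3)cc2)=NN1` share one core and differ only in the linker to the chlorophenyl group. In an assay on cells for inhibition of Amine oxidase [flavin-containing] A (Homo sapiens), read by Amplex Red, with a stated time of 30 min (a higher number here means a weaker inhibitor, a lower number a stronger inhibitor), compound 1 gives only a limit, > 100000 nM. Compound 2 likewise gives only a limit in this assay, > 100000 nM. Compound 2 thus stands at the limit of > 100000 nM in this assay, at which 2 of the 2 values shown sit, with no number to rank it. Compound 3 `Cc1cccc(/C=N/c2ccc(C3=NNC(=O)CO3)cc2)c1` differs from compound 2 by methyl in place of chloro on an aromatic carbon. For the measured compounds named here, no measured step exists here, so compound 3 is expected to stay at the limit, with a step of a number no higher from compound 2 to compound 3 (the limit leaves the size open) not beyond the scatter. Compound 3 is estimated at 100000 nM, within 30000 nM to 300000 nM.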

Compound 3, half-maximal inhibitory concentration: > 100000 nM
Compound 3: no number, only a limit; the forecaster's own chance of this, stated with the estimate: 85%; the middle value lies on the limit itself.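

For the compounds shown here, compound 2 and compound 3 both give only a limit in this assay, and no step between them can be read. The compounds shown leave open whether the linker or the change from 3-chlorophenyl to 3-methylphenyl alters inhibition at all.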